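Thiophene position swap on a nucleoside-like core and cytotoxicity

The source may report more compounds than this note shows. Statements on the series, on what has been measured and on what is new or still open speak of the compounds shown alone.

Compound 1 `OC[C@H]1O[C@@H](n2cc(Cl)c3c(-c4cccs4)ncnc32)[C@H](O)[C@@H]1O` and compound 2 `OC[C@H]1O[C@@H](n2cc(Cl)c3c(-c4ccsc4)ncnc32)[C@H](O)[C@@H]1O` share a core and differ only by one change, (thiophen-3-yl in place of thiophen-2-yl on an aromatic carbon). Compound 3 `CCCCCCCCCCCCCCCCCCOP(=O)(O)OC[C@H]1O[C@@H](n2ccc3c(-c4cccs4)ncnc32)[C@H](O)[C@@H]1O` carries a long phosphate-bearing chain on the same sugar and the thiophen-2-yl group; the difference between the core of compound 3 and the core of compound 1 is not broken down here. Compound 4 `CCCCCCCCCCCCCCCCCCOP(=O)(O)OC[C@H]1O[C@@H](n2ccc3c(-c4ccsc4)ncnc32)[C@H](O)[C@@H]1O` stands to compound 3 as compound 2 stands to compound 1, through the same kind of change, (thiophen-3-yl in place of thiophen-2-yl on an aromatic carbon).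

In an ADME assay on MRC5 cells (Homo sapiens) for cytotoxicity, read by MTT assay, with a stated time of 72 h (on this read-out higher numbers stand for lower toxicity in this test and lower numbers for higher toxicity in this test), compound 1 gives > 50000 nM, which is a limit of the assay and not a number. In this assay compound 2 gives > 50000 nM, also a limit. The step that the two limits leave unreadable from compound 1 to compound 2 therefore cannot be read, as the limit of > 50000 nM in this assay, at which 2 of the 3 values shown sit, shows. For compound 3 the result in this assay is "not determined" (no result reported).

Within the data shown here, since the only measured example of this change left both values at the limit, the step from compound 3 to compound 4 is expected to be small or unreadable in this assay. Compound 4 is estimated to give 50000 nM in this assay, likely again reported as a limit.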

Compound 4, half-maximal cytotoxic concentration: > 50000 nM
Compound 4 gave a limit, no number (the forecaster's own chance of this, stated with the estimate: 75%); the middle value lies on the limit itself.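

Among these compounds, no step from compound 3 to compound 4 can be read in this assay. Compound 4 gives > 50000 nM, which is a limit and not a number, and the values shown gather there: the limit of > 50000 nM in this assay, at which 3 of the 4 values shown sit.

The compounds shown leave open whether thiophen-3-yl in place of thiophen-2-yl changes the cytotoxicity at all in this assay.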